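The compounds below may be only part of what the source reports. "The series", "measured", "known", "first", "only" and "open" are said of these compounds alone.

Measured so far in a functional assay on the whole organism (strain CD-1) with Mus musculus as the target, in the maximal electroshock model, with a stated time of 0.5 h; a lower number here means that less compound is needed, a higher number that more compound is needed for the effect: compound 1 `CC1(c2ccccc2)CC(=O)N(CC(=O)N2CCOCC2)C1=O` gives 300 mg/kg; compound 2 `CC1(c2ccccc2)CC(=O)N(CC(=O)N2CCN(c3ccccc3Cl)CC2)C1=O` gives "not active" (no number reported); compound 3 `CC1(c2ccccc2)CC(=O)N(CC(=O)N2CCN(c3ccc(F)cc3)CC2)C1=O` gives 100 mg/kg.

Compound 3 has the lower of the two numbers reported; compound 1 is its nearest neighbour with a higher number, a gap that lies beyond the usual scatter. Compound 2 is reported without a number. Compound 4 `Cc1cccc(N2CCN(C(=O)CN3C(=O)CC(C)(c4ccccc4)C3=O)CC2)c1` is not yet measured. It differs from compound 3 as follows: 3-methylphenyl in place of 4-fluorophenyl on an amine nitrogen in a ring. Among the compounds with values here, no pair of measured compounds shows this kind of change, so the expectation rests on compound 3 alone. A step from compound 3 to compound 4 of a 1.5-fold higher number from compound 3 to compound 4 (0.18 log units; within the scatter) is expected, modest and toward a higher number, not clearly beyond the scatter. Compound 4 is therefore estimated at 150 mg/kg, with a range from 75 mg/kg to 300 mg/kg.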

Compound 4, minimum effective dose: 100 mg/kg
Compound 4: middle estimate off by 1.5-fold (0.18 log units), on the high side; low and high end bracket the measured number.
By their numbers in this assay, from the lowest: compounds 3 and 4 (each within the scatter of the next); then compound 1.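

In this assay, within the data shown here, 3-methylphenyl in place of 4-fluorophenyl on an amine nitrogen in a ring gives no change at the digits printed from compound 3 to compound 4 (within the scatter) and is the first step that can be read at this position. It shows that, for this pair, a methyl-bearing aryl group and a fluorine-bearing one give the same printed number on the shared core. Nothing available bears on why these two groups match.

On these data alone, what a phenyl group without a substituent, a pyridyl ring or a benzyl group would give on this nitrogen stays open.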